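Removing the Aryl Group from the Compound with the Highest Swelling Inhibition Number

This account rests on a few compounds, and the source may have more. Where it says the series, first, only, none or still open, it means among the compounds named here.

Of the compounds shown here, three that share one core have been tested in a functional assay on the whole organism (strain Wistar) for inhibition, with Rattus norvegicus as the target, read by paw edema, with stated times of 1 h and 4 h, at a dose of 70 mg/kg by the oral route; a higher number here means more inhibition at the dose given (going by the name of the read-out), a lower number less inhibition. Compound 1 `Clc1ccc2nc(Nc3nnc(-c4ccccc4Cl)o3)sc2c1` gives 53.2%. Compound 2 `Clc1ccc(-c2nnc(Nc3nc4ccc(Cl)cc4s3)o2)c(Cl)c1` gives 87.1%, the highest of the three numbers; compound 3 `CC.O=[N+]([O-])c1ccc(-c2nnc(Nc3nc4ccc(Cl)cc4s3)o2)cc1` gives 32.5%, the lowest. Among the compounds with values here, the only pair that differs in a single place is compound 1 and compound 2, where chloro in place of hydrogen on an aromatic carbon gave a number 33.9 percentage points higher from compound 1 to compound 2 (beyond the scatter).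

Compound 4 `Sc1nnc(Nc2nc3ccc(Cl)cc3s2)o1` has not yet been measured. It differs from compound 2 in one place: sulfanyl in place of 2,4-dichlorophenyl on an aromatic carbon. The whole six-membered aromatic ring of carbon only, with its two chlorine atoms, leaves, and a single sulfur bearing one hydrogen-bond donor and one hydrogen-bond acceptor enters on the five-membered aromatic ring.

Within the data shown here, no measured step covers loss of the whole aryl group. Among the measured compounds shown here, the one step that bears on this part of the structure, from compound 1 to compound 2, shows that even a single chloro on that ring moved the number by a large amount, so taking the ring away altogether is expected to cost inhibition. Compound 4 is therefore expected to give 38%, between 15% and 62%, a fall of a number 49.1 percentage points lower from compound 2 to compound 4 (beyond the scatter).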

Compound 4, a percentage reported as inhibition, in the whole organism at one dose (the size of the read-out at that dose, not a potency): 69.8%
Compound 4: middle estimate off by 31.8 percentage points, on the low side; the measured number lies above the stated range.
By their numbers in this assay, from the lowest: compound 3; then compound 1; then compound 4; then compound 2.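

In this assay, the whole aryl group turns out not to be needed for a sizeable number at this position. Sulfanyl in place of 2,4-dichlorophenyl gives a number 17.3 percentage points lower from compound 2 to compound 4 (beyond the scatter), while sulfanyl in place of 2-chlorophenyl gives a number 16.6 percentage points higher from compound 1 to compound 4 (beyond the scatter). Losing the ring therefore has no single direction: the outcome depends on which aryl group leaves, and nothing measured here explains why.

The compounds shown leave open whether the sulfur atom itself matters or whether other groups without a ring would do as well. An amine, a hydroxyl or a methyl on the same aromatic carbon could separate those two readings, and a 4-chlorophenyl group there would show how much each chlorine contributes.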